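The source may hold more compounds than are shown below. What is called first, only, known or untested is meant among the compounds shown, and "the series" means these compounds.

Compound 1 `Cn1cc(-c2cnc3c(-c4csc(C(=O)N[C@@H]5CCC[C@H]5O)c4)cnn3c2)cn1` gives 10 nM in an assay for inhibition of MAP/microtubule affinity-regulating kinase 3 (Homo sapiens), read by HTRF, with a stated time of 2 h; a lower number here means a stronger inhibitor, a higher number a weaker inhibitor.
Compound 2 `Cn1cc(-c2cnc3c(-c4csc(C(=O)N[C@@H]5CCCC[C@H]5O)c4)cnn3c2)cn1` gives 24 nM in this assay.
Compound 3 `Cn1cc(-c2cnc3c(-c4csc(C(=O)NC(CO)C5CC5)c4)cnn3c2)cn1` gives 9 nM in this assay.

Compound 3 has the lowest number of the three measured, but its gap to compound 1 is within the scatter; only compound 2 sits clearly apart, as the step of a 2.7-fold lower number from compound 2 to compound 3 (0.43 log units; beyond the scatter) shows. Compound 4 `Cn1cc(-c2cnc3c(-c4csc(C(=O)N[C@@H]5CCCC[C@H]5N)c4)cnn3c2)cn1` differs from compound 3 in one place: a group of 7 heavy atoms (6 carbon, 1 nitrogen; one six-membered non-aromatic ring of carbon only) in place of a group of 6 heavy atoms (5 carbon, 1 oxygen; one three-membered non-aromatic ring of carbon only), on an amide-type nitrogen. Among the compounds with values here, two measured steps bear on this change. Going from 2-hydroxycyclopentyl to 2-hydroxycyclohexyl gave a 2.4-fold higher number from compound 1 to compound 2 (0.38 log units; beyond the scatter), and replacing that six-membered ring by the three-membered group gave a 2.7-fold lower number from compound 2 to compound 3 (0.43 log units; beyond the scatter). Within the data shown here, compound 4 carries a 2-aminocyclohexyl where compound 2 carries a 2-hydroxycyclohexyl; no measured pair shows what exchanging the oxygen of that ring for nitrogen does, so that part of the change is uncharted. A modest rise in the number is therefore expected for compound 4, roughly a 2.8-fold higher number from compound 3 to compound 4 (0.44 log units; beyond the scatter). Compound 4 is estimated at 25 nM, with a range from 8 nM to 80 nM in this assay.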

Compound 4, half-maximal inhibitory concentration: 1 nM
Compound 4: middle estimate off by 25-fold (1.40 log units), on the high side; the measured number lies below the stated range.
By their numbers in this assay, from the lowest: compound 4; then compounds 3 and 1 (each within the scatter of the next); then compound 2.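

The clearest reading comes from the one-place exchange on the six-membered ring: 2-aminocyclohexyl in place of 2-hydroxycyclohexyl gives a 24-fold lower number from compound 2 to compound 4 (1.38 log units; beyond the scatter) in this assay, a larger step than the earlier changes of ring on this amide-type nitrogen. The 2-aminocyclohexyl group also outdoes the other two groups, with a 9.0-fold lower number from compound 3 to compound 4 (0.95 log units; beyond the scatter) and a 10-fold lower number from compound 1 to compound 4 (1.00 log units; beyond the scatter) as well, which makes compound 4 the strongest of the four. Nothing measured here explains this gain.

Going by these compounds, it remains open whether the gain needs a free amine, since a methylamino, dimethylamino or acetamido group on the same ring would test that. Also open, on these data alone, are how a 2-aminocyclopentyl group would compare and whether the other arrangements of the 2 stereocentres of 2-aminocyclohexyl hold the gain.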